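Chloro to Fluoro: Expecting Little Change in Antiproliferative Potency

The compounds below may be only part of what the source reports. "The series", "measured", "known", "first", "only" and "open" are said of these compounds alone.

Compound 1, `Nc1nc(N)c2cc(CSC(=S)N3CCN(c4ccccc4)CC3)ccc2n1`: 4120 nM
Compound 2, `Nc1nc(N)c2cc(CSC(=S)N3CCN(c4ccc(Cl)cc4)CC3)ccc2n1`: 7380 nM

In a functional assay on HCT-116 cells (Homo sapiens) for antiproliferative activity, read by MTT assay, with a stated time of 72 h (a higher number here means a weaker inhibitor, a lower number a stronger inhibitor), compound 2 gives the higher of the two measured numbers, but the step of a 1.8-fold higher number from compound 1 to compound 2 (0.25 log units; within the scatter) is within the scatter, so the two compounds cannot be told apart. Compound 3, `Nc1nc(N)c2cc(CSC(=S)N3CCN(c4ccc(F)cc4)CC3)ccc2n1`, differs from compound 2 by fluoro in place of chloro on an aromatic carbon. Within the data shown here, the only measured step that bears on this change is a 1.8-fold higher number from compound 1 to compound 2 (0.25 log units; within the scatter), and it stayed within the scatter. The step of a 1.3-fold lower number from compound 2 to compound 3 (0.13 log units; within the scatter) is therefore expected to stay within the scatter as well, in no clear direction. Compound 3 is estimated at 5500 nM, with a range from 2500 nM to 12000 nM.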

Compound 3, half-maximal inhibitory concentration: 3270 nM
Beside the measured number, compound 3's estimate is 1.7-fold (0.23 log units) above it; low and high end bracket the measured number.
By their numbers in this assay, from the lowest: compounds 3, 1 and 2 (each within the scatter of the next, the first and the last beyond it).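

In this assay, among these compounds, going from 4-chlorophenyl to 4-fluorophenyl gives a 2.3-fold lower number from compound 2 to compound 3 (0.35 log units; beyond the scatter), the first step at this position to clear the scatter, though only modestly. Fluoro in place of hydrogen gives a 1.3-fold lower number from compound 1 to compound 3 (0.10 log units; within the scatter), so these two compounds cannot be told apart, and the two halogens differ from each other more clearly than either differs from hydrogen. Nothing measured here explains the gap between chloro and fluoro.

From the compounds shown here alone, whether bromo, methoxy or an amine at the same place would track chloro or fluoro remains open. So does whether fluoro elsewhere on this ring would give a similar number.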